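The source may report more compounds than this note shows. Statements on the series, on what has been measured and on what is new or still open speak of the compounds shown alone.

Compound 1 `CCN(CC)CCCNC(=O)c1ccc(C(CC)(CC)c2ccc(OCC(=O)C(C)(C)C)c(C)c2)n1CC` gives 22 nM in an assay on HL-60 cells for agonist activity at vitamin D3 receptor (Homo sapiens), read by microscopy, with a stated time of 96 h; on this read-out higher numbers stand for an effect only at larger amounts of compound and lower numbers for an effect already at smaller amounts.
Compound 2 `CCn1c(C(=O)OC(C)CCO)ccc1C(CC)(CC)c1ccc(OCC(=O)C(C)(C)C)c(C)c1` gives 380 nM in this assay.
Compound 3 `CC[C@@H](C)[C@H](NC(=O)c1ccc(C(CC)(CC)c2ccc(OCC(=O)C(C)(C)C)c(C)c2)n1CC)C(=O)O` gives 10 nM in this assay.

Of the three measured compounds, compound 3 stands with the lowest number: the step of a 2.2-fold lower number from compound 1 to compound 3 (0.34 log units; beyond the scatter) is modest, while the step of a 38-fold lower number from compound 2 to compound 3 (1.58 log units; beyond the scatter) is large. Compound 4 `CCOc1ccc(NC(=O)c2ccc(C(CC)(CC)c3ccc(OCC(=O)C(C)(C)C)c(C)c3)n2CC)cc1` has not yet been measured. It differs from compound 3 in one place: 4-ethoxyphenyl in place of 1-carboxy-2-methylbutyl on an amide-type nitrogen. For the measured compounds named here, the only measured step that touches the same position is the one between compound 1 and compound 3, where a change of the group on the amide-type nitrogen moved the number only modestly, a 2.2-fold lower number from compound 1 to compound 3 (0.34 log units; beyond the scatter). The large step of a 38-fold lower number from compound 2 to compound 3 (1.58 log units; beyond the scatter) concerns a replacement on the carbonyl carbon and so says little about this exchange. On that basis a modest step is expected for compound 4 in this assay, more likely towards a higher number than towards a lower one, and the step of a 3.0-fold higher number from compound 3 to compound 4 (0.48 log units; beyond the scatter) is the estimated size. Compound 4 is therefore expected to give about 30 nM, within a range from 8 nM to 120 nM.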

Compound 4, half-maximal effective concentration: > 50000 nM
Compound 4: only a limit was reported (the forecaster's own chance of this, stated with the estimate: 5%); middle value at least 1600-fold (3.22 log units) from the limit.
By their numbers in this assay, from the lowest: compound 3; then compound 1; then compound 2. At a limit, above all of these: compound 4.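

For compound 4, only a limit was reported in this assay: the limit of > 50000 nM in this assay, at which 1 of the 4 values shown sits. For the compounds shown here, the group on the amide-type nitrogen, which had moved the number only modestly among the earlier compounds, therefore turns out to matter greatly: 4-ethoxyphenyl gives an at least 5000-fold higher number from compound 3 to compound 4 (3.69 log units; beyond the scatter) and an at least 2200-fold higher number from compound 1 to compound 4 (3.35 log units; beyond the scatter). Going by these compounds alone, the wider replacement on the carbonyl carbon is also large, with an at least 130-fold higher number from compound 2 to compound 4 (2.11 log units; beyond the scatter), so the one compound of the four carrying an aromatic ring in this group stands apart from all three without one.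

The compounds shown do not separate the contribution of the aromatic ring from that of its ethoxy group, nor show whether the carboxylic acid or the amine of the earlier groups is needed. A plain phenyl, a benzyl or a phenyl bearing a carboxylic acid on the same nitrogen would bear on these questions.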